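Ester chain length and cell viability in one series

This account rests on a few compounds, and the source may have more. Where it says the series, first, only, none or still open, it means among the compounds named here.

Compound 1 `CCOC(=O)CCC(=O)N1CCN(CCCOc2cc3c(Nc4ccc(F)c(Cl)c4)ncnc3cc2OC)CC1` gives 35.6% in a functional assay on A549 cells (Homo sapiens) for cytotoxicity, read by MTT assay, with a stated time of 24 h, tested at 80 uM; a higher number here means a weaker effect of the compound at the concentration tested, a lower number a stronger effect. Compound 2 `CCCCCCCCCCCOC(=O)CCC(=O)N1CCN(CCCOc2cc3c(Nc4ccc(F)c(Cl)c4)ncnc3cc2OC)CC1` gives 2.8% in this assay, the lower of the two numbers. Among the measured compounds shown here, the one measured step, a number 32.8 percentage points lower from compound 1 to compound 2 (beyond the scatter), was large. Compound 3 `CCCCCCCCCCCCCCCCCCCOC(=O)CCC(=O)N1CCN(CCCOc2cc3c(Nc4ccc(F)c(Cl)c4)ncnc3cc2OC)CC1` differs from compound 2 by octyl in place of hydrogen on a saturated chain carbon, ten or more bonds along the chain from an oxygen next to a carbonyl group. That measured step bears on the new one only loosely, since the read-out of compound 2 already leaves little room to fall further. For compound 3 the expected step of a number 2.2 percentage points higher from compound 2 to compound 3 (within the scatter) is therefore small, within the scatter. Compound 3 is estimated at 5%, between 0% and 20%.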

Compound 3, a percentage reported as activity, at one concentration (the size of the read-out at that concentration, not a potency): 88.4%
Estimate against measurement, compound 3: 83.4 percentage points below; the whole stated range lies below it.
By their numbers in this assay, from the lowest: compound 2; then compound 1; then compound 3.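

At this position, chain length does not act in one direction: adding octyl far along the chain gives a number 85.6 percentage points higher from compound 2 to compound 3 (beyond the scatter) in this assay and so reverses a number 32.8 percentage points lower from compound 1 to compound 2 (beyond the scatter). Lengthening lowers the number up to compound 2, while compound 3 goes against any steady downward trend. Nothing available accounts for this reversal.

Where the turn lies between the chains of compound 2 and compound 3 remains open. So does whether a carboxylic acid or an amine at the end of the chain would retain the low number of compound 2.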